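From Cyclic to Acyclic Amine on the Thiocarbonyl Carbon

The source may report more compounds than this note shows. Statements on the series, on what has been measured and on what is new or still open speak of the compounds shown alone.

Compound 1 `O=c1c(CSC(=S)N2CCN(c3ccccc3)CC2)coc2ccccc12` — 16700 nM
Compound 2 `CN1CCN(C(=S)SCc2coc3ccccc3c2=O)CC1` — 2400 nM

In a functional assay on HEp-2 cells (Homo sapiens) for antiproliferative activity, read by MTT assay, with a stated time of 72 h (on this read-out lower numbers stand for stronger inhibition and higher numbers for weaker inhibition), compound 2 gives 2400 nM, the lowest of the two numbers available. Its nearest neighbour is compound 1, which gives 16700 nM. Among the measured compounds shown here, the single measured step, a 7.0-fold lower number from compound 1 to compound 2 (0.84 log units; beyond the scatter), arises from methyl in place of phenyl on an amine nitrogen in a ring.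

Compound 3 `CC(C)N(C(=S)SCc1coc2ccccc2c1=O)C(C)C` differs from compound 2 by diisopropylamino in place of 4-methylpiperazin-1-yl on a thiocarbonyl carbon. For the measured compounds named here, no measured step bears on this exchange: the one step known concerns the substituent on the ring nitrogen, not the loss of the ring itself, so it gives no direction for compound 3. On this basis a step of no more than the usual scatter in either direction is expected. For compound 3 the estimate is 3000 nM, with a range from 800 nM to 12000 nM, which corresponds to an expected step of a 1.3-fold higher number from compound 2 to compound 3 (0.10 log units; within the scatter).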

Compound 3, half-maximal inhibitory concentration: 3000 nM
Compound 3: middle estimate and measured number agree at the digits printed; the range from low to high includes it.
By their numbers in this assay, from the lowest: compounds 2 and 3 (each within the scatter of the next); then compound 1.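

In this assay, diisopropylamino in place of 4-methylpiperazin-1-yl on the thiocarbonyl carbon gives a 1.3-fold higher number from compound 2 to compound 3 (0.10 log units; within the scatter). The earlier step, a 7.0-fold lower number from compound 1 to compound 2 (0.84 log units; beyond the scatter), concerned only the substituent on the ring nitrogen, whereas this exchange shows that neither the ring nor its second nitrogen is required at this place for a number within the scatter of compound 2. No evidence is available on what underlies this result.

From the compounds shown here alone, it remains open whether a smaller acyclic group such as dimethylamino, or a ring with a single nitrogen such as piperidin-1-yl, would also stay within that range. Equally open, going by these compounds, is what a methoxy group or a chlorine atom on the shared core would do to the number in this assay.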